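The source may hold more compounds than are shown below. What is called first, only, known or untested is meant among the compounds shown, and "the series" means these compounds.

Three compounds that share one core and differ in a single chain have been measured in a functional assay on SH-SY5Y cells (Homo sapiens) for antagonist activity, read by cAMP accumulation; a lower number here means a less potent compound, a higher number a more potent compound, by a factor of ten per unit of this negative logarithm. Compound 1 `CCCCOc1ccc(Cc2ccc(NC3=NCCN3)cc2)cc1` gives 9, compound 2 `CCCCCCOc1ccc(Cc2ccc(NC3=NCCN3)cc2)cc1` gives 8.2, and compound 3 `c1ccc(COc2ccc(Cc3ccc(NC4=NCCN4)cc3)cc2)cc1` gives 7.7. Compound 3 therefore stands lowest of the three, and its gaps to both of the others lie beyond the usual scatter.

Compound 4 `FC(F)(F)COc1ccc(Cc2ccc(NC3=NCCN3)cc2)cc1` has not yet been measured. It carries trifluoromethyl in place of phenyl on a saturated chain carbon bound to an oxygen on an aromatic ring.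

Going by the values given here, no measured step makes this exact exchange, so the evidence is indirect. Putting phenyl in place of propyl gave a number 1.30 log units lower from compound 1 to compound 3 (beyond the scatter), and putting phenyl in place of pentyl gave a number 0.50 log units lower from compound 2 to compound 3 (beyond the scatter). Adding ethyl to the chain gave a number 0.80 log units lower from compound 1 to compound 2 (beyond the scatter). Read in reverse, the first two steps suggest that replacing phenyl with a group without a ring may raise the number, but neither propyl nor pentyl is trifluoromethyl, and no measured compound here contains fluorine. A modest rise in this assay is therefore expected, and the estimated step is a number 0.60 log units higher from compound 3 to compound 4 (beyond the scatter). For compound 4 the estimate is 8.3, with an expected range from 7.6 to 9.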

Compound 4, negative logarithm of the antagonist equilibrium constant: 8.7
Estimate against measurement, compound 4: 0.40 log units below, and the stated range covers the measured number.
By their numbers in this assay, from the lowest: compound 3; then compound 2; then compounds 4 and 1 (each within the scatter of the next).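

Until now, every group at this place other than phenyl had been a plain carbon chain, so it was unclear whether a high number needed such a chain. Trifluoromethyl on the saturated chain carbon bound to an oxygen on an aromatic ring settles that for this assay: in place of phenyl it gives a number 1.00 log units higher from compound 3 to compound 4 (beyond the scatter), and in place of pentyl it gives a number 0.50 log units higher from compound 2 to compound 4 (beyond the scatter), so a group with no ring and no long chain can stand clear of both compound 3 and compound 2. In place of propyl it gives a number 0.30 log units lower from compound 1 to compound 4 (within the scatter), which means that, in this read-out, this fluorine-bearing group and the propyl of compound 1 cannot be told apart.

Nothing measured on these compounds speaks to why the numbers fall as they do. From the compounds shown here alone, it also remains open whether cyclohexyl at this place would sit low like phenyl or high like trifluoromethyl, and whether methyl, or a group with an amine or a carboxylic acid, would hold the number up.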